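The compounds below may be only part of what the source reports. "The series", "measured", "known", "first", "only" and "open" are said of these compounds alone.

Measured so far:
- compound 1 `CNc1cc(Oc2ccc(NC(=O)Nc3cccc(C(F)(F)F)c3)c(F)c2)ncn1`: 63 nM
- compound 2 `O=C(Nc1ccc(Oc2cc(O)ncn2)cc1)Nc1cccc(C(F)(F)F)c1`: 3200 nM

Both compounds share the diaryl urea with a trifluoromethyl group and an aryl ether linking to the same six-membered aromatic ring with two nitrogens. In an assay on isolated protein for inhibition of serine/threonine-protein kinase TNNI3K (Homo sapiens) (on this read-out lower numbers stand for stronger inhibition and higher numbers for weaker inhibition), compound 1 gives 63 nM and compound 2 gives 3200 nM. Among the measured compounds shown here, compound 2 therefore carries the highest of the two numbers, and its nearest neighbour, compound 1, sits far below it, well beyond the scatter; the two differ in more than one place, so no single step between them is tallied, and their two values alone are what the series shows.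

Compound 3 `O=C(Nc1ccc(Oc2cc(NCCO)ncn2)cc1)Nc1cccc(C(F)(F)F)c1` is the next entry and has not yet been measured in this assay. It differs from compound 2 at one point on the six-membered aromatic ring with two nitrogens: (2-hydroxyethyl)amino in place of hydroxy on an aromatic carbon.

Given that compound 2 gives 3200 nM while compound 1, which carries an amino substituent at that position, gives 63 nM, the expectation for compound 3 is a step of a 21-fold lower number from compound 2 to compound 3 (1.33 log units; beyond the scatter) in this assay, downward and beyond the scatter. Compound 3 is estimated at 150 nM, with a range of 40 nM to 600 nM.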

Compound 3, half-maximal inhibitory concentration: 32 nM
Compound 3: middle estimate off by 4.7-fold (0.67 log units), on the high side; measured number below the stated range.
By their numbers in this assay, from the lowest: compounds 3 and 1 (each within the scatter of the next); then compound 2.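

In this assay, among the compounds shown here, the change from hydroxy to (2-hydroxyethyl)amino on this aromatic carbon gives a 100-fold lower number from compound 2 to compound 3 (2.00 log units; beyond the scatter), and this is the first step that can be read at a single place. It shows that this carbon of the six-membered aromatic ring with 2 nitrogen is sensitive: with the rest of compound 2 held constant, the substituent here moves the number far beyond the scatter, and a group of 4 heavy atoms is accepted in place of one of 1 heavy atom. No measurement on hand accounts for the size of this step.

On these data alone, the step cannot separate the parts of the entering group, since the ring-bound nitrogen, the two-carbon chain and the hydroxy all arrive together, so it remains open whether a plain amino group, an ethylamino group or a (2-methoxyethyl)amino group would give a similar number. Also open, as far as these compounds go, is how far this position tolerates further growth, for example a longer chain such as (3-hydroxypropyl)amino, a cyclic amine such as morpholine, or a carboxylic acid at the end of the chain.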